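The source may hold more compounds than are shown below. What is called first, only, known or untested is meant among the compounds shown, and "the series" means these compounds.

Measured in a functional assay on HUVEC cells (Homo sapiens), read by BrdU incorporation, with a stated time of 72 h; a higher number here means a weaker inhibitor, a lower number a stronger inhibitor:
- Compound 1 `Cc1cc(C(=O)/C=C/c2cc3cccc(C)c3nc2Cl)c(C)s1`: "not determined" (no result reported)
- Compound 2 `Cc1ccc2cc(/C=C/C(=O)c3ccc(Br)s3)c(Cl)nc2c1`: 83.6 nM
- Compound 3 `Cc1ccc2nc(Cl)c(/C=C/C(=O)c3cc(C)sc3C)cc2c1`: 229 nM

Compound 3, at 229 nM, holds the higher of the two numbers available, so it is the weaker inhibitor of the pair. Its nearest neighbour is compound 2 at 83.6 nM, and the gap between them lies beyond the usual scatter. Compound 1 offers no number for comparison.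

The next compound to be tested is compound 4 `Cc1ccc2nc(Cl)c(/C=C/C(=O)c3ccc(C)s3)cc2c1`. It carries 5-methylthiophen-2-yl in place of 2,5-dimethylthiophen-3-yl on a carbonyl carbon. For the measured compounds named here, no measured pair differs in one place only, so the series offers no direct precedent for this change. Going by the values given here, the only guide is compound 2 at 83.6 nM, which shows that a lower number is reachable. A modest shift toward a lower number is therefore expected in this assay, of a size close to the scatter, and the estimated step is a 1.8-fold lower number from compound 3 to compound 4 (0.25 log units; within the scatter). For compound 4 the estimated value is 130 nM, with an expected range from 45 nM to 380 nM.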

Compound 4, half-maximal inhibitory concentration: 128 nM
Compound 4: the middle estimate sits 1.0-fold (0.01 log units) above what was measured; low and high end bracket the measured number.
By their numbers in this assay, from the lowest: compounds 2, 4 and 3 (each within the scatter of the next, the first and the last beyond it).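

In this assay, for the compounds shown here, this is the first comparison between compounds that differ in one place: 5-methylthiophen-2-yl in place of 2,5-dimethylthiophen-3-yl on a carbonyl carbon gives a 1.8-fold lower number from compound 3 to compound 4 (0.25 log units; within the scatter). On this evidence, the two groups cannot be told apart at this position, so this particular change leaves the number within the usual scatter. No measurement at hand offers an explanation for this result.

Going by these compounds, whether a carboxylic acid, an amine or a plain phenyl ring on the same carbonyl carbon would keep the number in this range remains open. Compound 2 differs from compound 4 in more than one place, so the gap between their values cannot be assigned to any single change.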